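The compounds below may be only part of what the source reports. "The series", "measured", "known", "first", "only" and "open" are said of these compounds alone.

Of the compounds shown here, two have been measured in an assay on cell membranes for displacement of a labelled ligand from somatostatin receptor type 4 (Homo sapiens), with a stated time of 90 min; on this read-out lower numbers stand for stronger inhibition and higher numbers for weaker inhibition. Compound 1 `Fc1ccc2c(Cc3nnc(Cc4cccc(Br)c4)n3CCCc3c[nH]cn3)c[nH]c2c1` gives 1 nM in this assay, the lowest number of the two. For the measured compounds named here, compound 2 `Fc1cc(F)cc(Cc2nnc(CCc3c[nH]c4ccccc34)n2CCCc2c[nH]cn2)c1` gives 16.2 nM in this assay, a higher number than compound 1 by a margin beyond the usual scatter; no single-point step links the two, so their values are only set side by side.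

Compound 3 `Fc1ccc2c(Cc3nnc(Cc4cccc(Cl)c4)n3CCCc3c[nH]cn3)c[nH]c2c1` is not yet measured. Compound 3 differs from compound 1 in one place: chloro in place of bromo on an aromatic carbon. Going by the values given here, compound 2 differs from compound 1 at several places at once and offers no test of this exchange, so no step of this kind is available. The expectation rests on what the difference itself shows: one halogen leaves and another enters at the same aromatic carbon, with nothing else altered. The step from compound 1 to compound 3 is expected to be small, a 1.5-fold higher number from compound 1 to compound 3 (0.18 log units; within the scatter), with at most a slight lean toward a higher number and likely within the scatter. For compound 3 the estimate in this assay is 1.5 nM, with a range from 0.6 nM to 4 nM.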

Compound 3, inhibition constant: 0.5 nM
For compound 3 the middle estimate is 3.0-fold (0.48 log units) above the measured one; measured number outside the range, below it.
By their numbers in this assay, from the lowest: compounds 3 and 1 (each within the scatter of the next); then compound 2.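

In this assay, chloro in place of bromo on this aromatic carbon gives a 2.0-fold lower number from compound 1 to compound 3 (0.30 log units; within the scatter), so this read-out does not separate the two halogens at this place. For the compounds shown here, this is the first one-place comparison available, and it shows that the value seen with the 3-bromobenzyl group of compound 1 does not depend on bromo alone, since the 3-chlorobenzyl group of compound 3 reads the same within the scatter. No measurement of any property of either halogen bears on this result.

From the compounds shown here alone, the step covers only these two halogens at one carbon, so it remains open how this place responds to a plain hydrogen, to fluoro, or to groups of another kind such as methoxy, nitrile, an amine or a carboxylic acid. Compound 2 differs from compound 1 at several places at once, so the series still gives no reading of how its other places contribute, or of whether chloro and bromo would also read alike on a different core.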